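From 3-isopropylphenyl to 2,4,6-trimethylphenyl on the shared core

The compounds below may be only part of what the source reports. "The series", "measured", "known", "first", "only" and "open" are said of these compounds alone.

Of the compounds shown here, three have been measured in a functional assay on MCF7 cells (Homo sapiens) for inhibition, read by CCK-8 assay, with a stated time of 48 h (on this read-out higher numbers stand for weaker inhibition of growth and lower numbers for stronger inhibition of growth), and a fourth is still to be measured.

Compound 1 `CN1CCN(c2ccc(Nc3ncc(Cl)c(NCc4ccc(C(F)(F)F)cc4)n3)nc2)CC1` gives 28400 nM
Compound 2 `Cc1cccc(Nc2nc(Nc3ccc(N4CCN(C)CC4)cn3)ncc2Cl)c1` gives 7160 nM
Compound 3 `CC(C)c1cccc(Nc2nc(Nc3ccc(N4CCN(C)CC4)cn3)ncc2Cl)c1` gives 8640 nM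

The step of a 1.2-fold higher number from compound 2 to compound 3 (0.08 log units; within the scatter) lies within the scatter, so the last two stand together. Both a 4.0-fold lower number from compound 1 to compound 2 (0.60 log units; beyond the scatter) and a 3.3-fold lower number from compound 1 to compound 3 (0.52 log units; beyond the scatter) go beyond it, and both are modest. Compound 4 `Cc1cc(C)c(Nc2nc(Nc3ccc(N4CCN(C)CC4)cn3)ncc2Cl)c(C)c1` has the same atoms as compound 3, joined differently, with 2,4,6-trimethylphenyl in place of 3-isopropylphenyl on a nitrogen on an aromatic ring. Among the measured compounds shown here, no measured compound carries 2,4,6-trimethylphenyl, so no step tests this change directly. The expectation therefore rests on compound 3 at 8640 nM and on the nearest evidence, a 1.2-fold higher number from compound 2 to compound 3 (0.08 log units; within the scatter) where only the group on the phenyl differs. In this assay the expected result is a 1.0-fold higher number from compound 3 to compound 4 (0.02 log units; within the scatter) and thus no step beyond the scatter in either direction. Compound 4 is estimated at 9000 nM within a range of 3500 nM to 25000 nM as the expected span.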

Compound 4, concentration for 50% growth inhibition: 9470 nM
Beside the measured number, compound 4's estimate is 1.1-fold (0.02 log units) below it; the range from low to high includes it.
By their numbers in this assay, from the lowest: compounds 2, 3 and 4 (each within the scatter of the next); then compound 1.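

In this assay, rearranging the same atoms from 3-isopropylphenyl into 2,4,6-trimethylphenyl on this nitrogen gives a 1.1-fold higher number from compound 3 to compound 4 (0.04 log units; within the scatter), and the comparison with the smaller 3-methylphenyl group gives a 1.3-fold higher number from compound 2 to compound 4 (0.12 log units; within the scatter), so the number stays within the scatter across all three phenyl groups despite their different patterns of substitution. The gap to the benzyl compound remains, with a 3.0-fold lower number from compound 1 to compound 4 (0.48 log units; beyond the scatter), so compounds 2, 3 and 4 together stand apart from compound 1 by a modest margin. No measurement at hand bears on why the change in substitution leaves the number where it is.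

The compounds shown leave open whether an amine or a carboxylic acid on the phenyl ring would move the number beyond the scatter. They also leave open what a benzyl group without trifluoromethyl would give at this nitrogen.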